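The source may hold more compounds than are shown below. What is called first, only, known or untested is meant among the compounds shown, and "the series" means these compounds.

Measured so far in a functional assay on A549 cells (Homo sapiens) for antiproliferative activity, read by MTT assay, with a stated time of 48 h; on this read-out higher numbers stand for weaker inhibition and lower numbers for stronger inhibition:
- compound 1 `N#CC1=C(N)Oc2c(N)cc3nc4ccccc4nc3c2C12C(=O)N(Cc1cnnn1-c1cccc(Br)c1)c1ccccc12`: 18900 nM
- compound 2 `CCOc1ccc(-n2nncc2CN2C(=O)C3(C(C#N)=C(N)Oc4c(N)cc5nc6ccccc6nc5c43)c3ccccc32)cc1`: the assay gives only a limit, > 50000 nM
- compound 3 `Cc1ccc(-n2nncc2CN2C(=O)C3(C(C#N)=C(N)Oc4c(N)cc5nc6ccccc6nc5c43)c3ccccc32)cc1C`: the assay gives only a limit, > 50000 nM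

Compound 3 therefore stands at the limit of this assay, not at a number; the same limit applies to compound 2 (the limit of > 50000 nM in this assay, at which 2 of the 3 values shown sit). Within the data shown here, only compound 1, bearing 3-bromophenyl on the aromatic nitrogen, gives a readable value, and the step of an at least 2.6-fold higher number from compound 1 to compound 3 (0.42 log units; beyond the scatter) is the only measured move onto compound 3, with a step that the two limits leave unreadable from compound 2 to compound 3 unreadable.

Compound 4 `N#CC1=C(N)Oc2c(N)cc3nc4ccccc4nc3c2C12C(=O)N(Cc1cnnn1-c1c(F)cccc1F)c1ccccc12` differs from compound 3 in one place: 2,6-difluorophenyl in place of 3,4-dimethylphenyl on an aromatic nitrogen. Among the measured compounds shown here, no measured pair covers this exchange directly. The one halogen-bearing phenyl in the set, compound 1, sits at a number, while both non-halogen phenyls sit at the limit, so the step of an at least 1.6-fold lower number from compound 3 to compound 4 (0.22 log units; that floor lies within the scatter) from compound 3 to compound 4 is expected to run toward a lower number, but its size rests on a limit and is uncertain. Compound 4 is estimated at 30000 nM, within 12000 nM to 80000 nM in this assay, with a real chance that only a limit is returned again.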

Compound 4, half-maximal inhibitory concentration: > 50000 nM
Compound 4 ended at the assay's limit; the forecaster's own chance of this, stated with the estimate: 45%; middle value at least 1.6-fold (0.22 log units) away from the limit.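

A halogen on the phenyl at this position does not by itself give a readable value in this assay: the 2,6-difluorophenyl of compound 4 returns only a limit, > 50000 nM. Setting 2,6-difluorophenyl in place of 3-bromophenyl gives an at least 2.6-fold higher number from compound 1 to compound 4 (0.42 log units; beyond the scatter), so compound 4 goes against any link between halogen and a readable number, and 3-bromophenyl remains the only group here with one. The steps among compound 2, compound 3 and compound 4 cannot be read, and the exchanges at this position now mostly end at the same limit: the limit of > 50000 nM in this assay, at which 3 of the 4 values shown sit.

A 3-chlorophenyl or a 4-bromophenyl would test whether the number of compound 1 depends on bromine itself or on where it sits. On these data alone, whether an amine or a carboxylic acid on the phenyl gives a readable value remains open.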